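The source may hold more compounds than are shown below. What is called first, only, known or untested is meant among the compounds shown, and "the series" means these compounds.

Of the compounds shown here, three built on a shared core have been measured in a functional assay on HL-60 cells (Homo sapiens) for antiproliferative activity, with a stated time of 24 h; on this read-out lower numbers stand for stronger inhibition and higher numbers for weaker inhibition. Compound 1 `NC(=O)c1c(NC(=O)c2ccccc2I)sc2c1CCN(C(=S)Nc1ccccc1Cl)C2` gives 8560 nM. Compound 2 `NC(=O)c1c(NC(=O)c2ccccc2C(F)(F)F)sc2c1CCN(C(=S)Nc1ccccc1Cl)C2` gives 17600 nM. Compound 3 `COc1ccccc1C(=O)Nc1sc2c(c1C(N)=O)CCN(C(=S)Nc1ccccc1Cl)C2` gives 20800 nM, the highest of the three numbers. Compound 4 `CSc1ccccc1C(=O)Nc1sc2c(c1C(N)=O)CCN(C(=S)Nc1ccccc1Cl)C2` differs from compound 3 by methylsulfanyl in place of methoxy on an aromatic carbon. Among the measured compounds shown here, no measured step exchanges these two groups directly; the steps at this position are a 2.1-fold higher number from compound 1 to compound 2 (0.31 log units; beyond the scatter), a 2.4-fold higher number from compound 1 to compound 3 (0.39 log units; beyond the scatter) and a 1.2-fold higher number from compound 2 to compound 3 (0.07 log units; within the scatter), so exchanges there moved this assay only modestly or not beyond the scatter. A step from compound 3 to compound 4 of about a 1.3-fold lower number from compound 3 to compound 4 (0.11 log units; within the scatter) is therefore expected, with no clear direction. Compound 4 is estimated at 16000 nM in this assay, within a range from 6000 nM to 40000 nM.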

Compound 4, half-maximal inhibitory concentration: 30500 nM
Estimate against measurement, compound 4: 1.9-fold (0.28 log units) below; the measured number falls inside the stated range.
By their numbers in this assay, from the lowest: compound 1; then compounds 2, 3 and 4 (each within the scatter of the next).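

In this assay, methylsulfanyl on this aromatic carbon, ortho to a large group, does not separate from methoxy (a 1.5-fold higher number from compound 3 to compound 4 (0.17 log units; within the scatter)) or from trifluoromethyl (a 1.7-fold higher number from compound 2 to compound 4 (0.24 log units; within the scatter)). Only iodo stands apart (a 3.6-fold higher number from compound 1 to compound 4 (0.55 log units; beyond the scatter)), so compound 1 now lies beyond the scatter from all three other compounds. Nothing given here explains this difference. From the compounds shown here alone, whether any group at this place gives a lower number than iodo remains open. So does the effect of an amine, a carboxylic acid or a longer chain such as ethoxy.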